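The source may hold more compounds than are shown below. What is called first, only, known or untested is meant among the compounds shown, and "the series" means these compounds.

In an ADME assay on MRC5 cells (Homo sapiens) for cytotoxicity, read by resazurin assay, with a stated time of 72 h (a higher number here means a weaker inhibitor, a lower number a stronger inhibitor), compound 2 `O=[N+]([O-])c1cn2c(n1)OC(COc1cccc(-c3ccc(F)cc3F)n1)CC2` gives > 64000 nM as a limit and not a number. Compound 1 `O=[N+]([O-])c1cn2c(n1)OC(COc1ccc(-c3ccc(F)nc3F)nc1)CC2` gives > 64000 nM as a limit too. Compound 3 `CC1(COc2cccc(-c3ccc(F)cc3F)n2)CCn2cc([N+](=O)[O-])nc2O1` gives > 64000 nM as a limit as well. Among the measured compounds shown here, the series so far is thus the limit of > 64000 nM in this assay, at which 3 of the 3 values shown sit, and offers no exact value. Compound 4 `O=[N+]([O-])c1cn2c(n1)OC(COc1cccc(-c3ccc(F)cc3)n1)CC2` differs from compound 2 by hydrogen in place of fluoro on an aromatic carbon in the change from 2,4-difluorophenyl to 4-fluorophenyl, with hydrogen in place of fluoro on an aromatic carbon. For the measured compounds named here, the one measured step is a step that the two limits leave unreadable from compound 2 to compound 3 and it is methyl in place of hydrogen on a saturated ring carbon, so it gives no size to carry over. No shift beyond the scatter is expected in this assay and the expected step is a number no higher from compound 2 to compound 4 (the limit leaves the size open) in size. The estimate for compound 4 is 64000 nM within an expected range from 30000 nM to 100000 nM and a reading at the limit is likely.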

Compound 4, half-maximal inhibitory concentration: 59000 nM
For compound 4 the middle estimate is 1.1-fold (0.04 log units) above the measured one; low and high end bracket the measured number.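

In this assay, among the compounds shown here, compound 4 gives 59000 nM, the only exact value shown for the series. Hydrogen in place of fluoro on this aromatic carbon, ortho to a large group, gives an at least 1.0-fold lower number from compound 2 to compound 4 (0.03 log units; that floor lies within the scatter), so the change from 2,4-difluorophenyl to 4-fluorophenyl brings a reading off the limit, though the true size of the step stays open. The other values are limits and not numbers: the limit of > 64000 nM in this assay, at which 3 of the 4 values shown sit.

The step for methyl in place of hydrogen on the saturated ring carbon cannot be read. On these data alone, whether an amine or a carboxylic acid on this aromatic carbon would move the number beyond the scatter remains open.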